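Nitro to Fluoro on the Sulfonyl Ring: Second Look

A few compounds are considered here, and "the series" means these few. Any claim that something is new, unique, unknown or untested is made for them only; others in the source may bear on it.

Measured so far:
Compound 1, `O=[N+]([O-])c1ccc(S(=O)(=O)n2c(-c3cn(-c4ccccc4)nc3-c3ccc(F)cc3)nc3ccccc32)cc1`, gives 1340 nM.
Compound 2, `O=S(=O)(c1ccc(F)cc1)n1c(-c2cn(-c3ccccc3)nc2-c2ccc(F)cc2)nc2ccccc21`, gives 3520 nM.
Compound 3, `O=[N+]([O-])c1ccc(S(=O)(=O)n2c(-c3cn(-c4ccccc4)nc3-c3ccc(C(F)(F)F)cc3)nc3ccccc32)cc1`, gives 1070 nM.

All three values come from a functional assay on HepG2 cells (Homo sapiens) for antiproliferative activity, read by MTT assay, with a stated time of 24 h; on this read-out higher numbers stand for weaker inhibition and lower numbers for stronger inhibition. Compound 1 and compound 2 differ in one place only: fluoro in place of nitro on an aromatic carbon. That single swap produced a 2.6-fold higher number from compound 1 to compound 2 (0.42 log units; beyond the scatter), so the fluoro compound gave the weaker result of the pair.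

Compound 3 carries a different core from compound 1. The two cores differ as follows: trifluoromethyl in place of fluoro on an aromatic carbon. That change produced a 1.3-fold lower number from compound 1 to compound 3 (0.10 log units; within the scatter), a gap that falls within the usual scatter of this kind of measurement, so compound 1 and compound 3 cannot be told apart on this read-out.

Compound 4, `O=S(=O)(c1ccc(F)cc1)n1c(-c2cn(-c3ccccc3)nc2-c2ccc(C(F)(F)F)cc2)nc2ccccc21`, is the one that remains to be tested in this assay. It differs from compound 3 exactly as compound 2 differs from compound 1: fluoro in place of nitro on an aromatic carbon. The place of the change is the same in both pairs, so this is the same change made on the core of compound 3.

Within the data shown here, with only one prior example of this swap, the expectation rests on that example alone: a 2.6-fold higher number from compound 1 to compound 2 (0.42 log units; beyond the scatter). A similar step is expected here, which would mean a 2.6-fold higher number from compound 3 to compound 4 (0.42 log units; beyond the scatter). On that basis compound 4 is estimated at 2800 nM, with the likely range running from 1400 nM to 6000 nM.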

Compound 4, half-maximal inhibitory concentration: 2730 nM
Estimate against measurement, compound 4: 1.0-fold (0.01 log units) above; the range from low to high includes it.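

The nitro to fluoro swap gave a 2.6-fold higher number from compound 3 to compound 4 (0.41 log units; beyond the scatter), so on these two cores the change carried over with its size intact: the same change on two cores in this assay, a 2.6-fold higher number (0.42 log units; beyond the scatter) from compound 1 to compound 2 and a 2.6-fold higher number (0.41 log units; beyond the scatter) from compound 3 to compound 4, 1.0-fold (0.01 log units) apart, within the scatter of two such steps. Read along the other edge of the set, trifluoromethyl in place of fluoro on an aromatic carbon gave a 1.3-fold lower number from compound 2 to compound 4 (0.11 log units; within the scatter), a gap within the scatter, so that change does not separate the compounds with either the nitro or the fluoro group in place: the same change on two cores in this assay, a 1.3-fold lower number (0.10 log units; within the scatter) from compound 1 to compound 3 and a 1.3-fold lower number (0.11 log units; within the scatter) from compound 2 to compound 4, 1.0-fold (0.01 log units) apart, within the scatter of two such steps. This shows that the two changes add up cleanly across these four compounds, but four compounds form only one such square, so it does not show that the step would keep its size on any other core, and it gives no reason why the fluoro compounds carry the higher numbers.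

The compounds shown leave open how an amine or a carboxylic acid in place of the nitro group would read in this assay. Also open, going by these compounds, is whether the nitro to fluoro step would stay the same with a methoxy group where compound 3 and compound 4 carry trifluoromethyl.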